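Thiazole ester series: ring swap and cytotoxicity on Huh-7

The source may hold more compounds than are shown below. What is called first, only, known or untested is meant among the compounds shown, and "the series" means these compounds.

Measured compounds:
- compound 1 `CC(C)OC(=O)c1sc(Nc2ncccn2)nc1-c1ccccn1`: 410 nM
- compound 2 `CC(C)OC(=O)c1sc(Nc2ncccn2)nc1-c1cnccn1`: 110 nM
- compound 3 `CC(C)OC(=O)c1sc(N(COP(=O)(OC(C)(C)C)OC(C)(C)C)c2ncccn2)nc1-c1ccccn1`: 380 nM

Three compounds of the series have been run in a functional assay on Huh-7 cells (Homo sapiens) for cytotoxicity, read by MTT assay, with a stated time of 72 h; on this read-out lower numbers stand for higher toxicity in this test and higher numbers for lower toxicity in this test. Compound 1 `CC(C)OC(=O)c1sc(Nc2ncccn2)nc1-c1ccccn1` gives 410 nM in this assay. Compound 2 `CC(C)OC(=O)c1sc(Nc2ncccn2)nc1-c1cnccn1` gives 110 nM. The two differ by one change, (pyrazin-2-yl in place of pyridin-2-yl on an aromatic carbon), and the step is a 3.7-fold lower number from compound 1 to compound 2 (0.57 log units; beyond the scatter). Compound 3 `CC(C)OC(=O)c1sc(N(COP(=O)(OC(C)(C)C)OC(C)(C)C)c2ncccn2)nc1-c1ccccn1` gives 380 nM; its value and that of compound 1 lie within the scatter of each other, so no order between them is claimed. How the cores of compound 1 and compound 3 differ is not broken down here.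

Compound 4 `CC(C)OC(=O)c1sc(N(COP(=O)(OC(C)(C)C)OC(C)(C)C)c2ncccn2)nc1-c1cnccn1` is not yet measured in this assay. It stands to compound 3 as compound 2 stands to compound 1: pyrazin-2-yl in place of pyridin-2-yl on an aromatic carbon. Within the data shown here, the change is the same kind of change as the one from compound 1 to compound 2, not the same one, for the surroundings differ: in compound 1 the ring atom two ring bonds away bears a (pyrimidin-2-yl)amino group (7 heavy atoms), whereas in compound 3 that ring atom bears a large group.

The same kind of change has been seen once among the measured compounds. Because the step of a 3.7-fold lower number from compound 1 to compound 2 (0.57 log units; beyond the scatter) was beyond the scatter, a step of similar direction and size is expected from compound 3 to compound 4, about a 2.9-fold lower number from compound 3 to compound 4 (0.47 log units; beyond the scatter). Compound 4 is estimated at 130 nM in this assay, with a range from 60 nM to 300 nM.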

Compound 4, half-maximal cytotoxic concentration: 980 nM
The estimate for compound 4 lay 7.5-fold (0.88 log units) below the measured number, outside the stated range (above it).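

On the core of compound 3, pyrazin-2-yl in place of pyridin-2-yl gives a 2.6-fold higher number from compound 3 to compound 4 (0.41 log units; beyond the scatter) in this assay, so the lower number seen on the core of compound 1 does not carry over and the direction of the step is reversed. The two steps therefore cannot be read as a single effect of this ring swap that holds across both cores: the same change on two cores in this assay, a 3.7-fold lower number (0.57 log units; beyond the scatter) from compound 1 to compound 2 and a 2.6-fold higher number (0.41 log units; beyond the scatter) from compound 3 to compound 4, 9.6-fold (0.98 log units) apart, beyond the scatter of two such steps. With one pair on each core, this shows that the result of the swap in this series depends on the core it is made on; it does not show which feature of the core sets the direction, nor how the swap would behave on any third core.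

Open, on these data alone, is whether a methyl, an acetyl or a free phosphoric acid group in place of the large group would give a step like the one on the core of compound 1 or the one on the core of compound 3. Also open, as far as these compounds go, is whether a phenyl or a pyrimidin-5-yl ring on the same aromatic carbon would split between the two cores in the same way.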